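The compounds below may be only part of what the source reports. "The series", "measured", "known", "first", "only" and "open" are said of these compounds alone.

Compound 3 `CCCNc1nc(N)nc2c1ncn2/C=C1/CC1(CO)CO` was tested in an ADME assay on HFF cells (Homo sapiens) for cytotoxicity, with a stated time of 8 days; on this read-out higher numbers stand for lower toxicity in this test and lower numbers for higher toxicity in this test. For compound 3 the read-out is only a limit, > 300000 nM. Compound 1 `CCCCCCCCOc1nc(N)nc2c1ncn2/C=C1/CC1(CO)CO` also gives only a limit there, > 300000 nM. Compound 2 `Nc1nc2c(ncn2/C=C2/CC2(CO)CO)c(=O)[nH]1` likewise gives only a limit, > 300000 nM. Compound 3 therefore stands level with both other compounds, with no number to set it apart. Among the measured compounds shown here, the only measured step, a step that the two limits leave unreadable from compound 1 to compound 3, cannot be read in size because both of its ends sit at the limit of > 300000 nM in this assay, at which 3 of the 3 values shown sit. Compound 4 `CCCCNc1nc(N)nc2c1ncn2/C=C1/CC1(CO)CO` differs from compound 3 by methyl in place of hydrogen on a saturated chain carbon, three bonds along the chain from a nitrogen on an aromatic ring. For the measured compounds named here, no measured step bears on this change, so no direction can be read from the data. Compound 4 is expected to stay at the same limit, an estimated step that the limit leaves unreadable from compound 3 to compound 4, with an estimate of 400000 nM between 200000 nM and 1000000 nM.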

Compound 4, half-maximal cytotoxic concentration: > 300000 nM
Compound 4: a limit, no number; the forecaster's own chance of this, stated with the estimate: 85%; the middle value lies beyond the limit too.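

The steps to compound 4 from compound 3 and from compound 1 cannot be read, because both ends of each step are limits, not numbers: the limit of > 300000 nM in this assay, at which 4 of the 4 values shown sit.

The compounds shown leave open whether changing these chains alters toxicity to the cells at all.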